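This account rests on a few compounds, and the source may have more. Where it says the series, first, only, none or still open, it means among the compounds named here.

In an ADME assay on BJ cells (Homo sapiens) for cytotoxicity, read by luminescence, with a stated time of 72 h (a higher number here means that more compound is needed for the effect, a lower number that less compound is needed), two compounds sharing one core have been read so far. Compound 1 `CCOC(=O)c1c(-c2cc(F)cc(OC)c2)[nH]c2cc(OC)ccc2c1=O` gives > 21500 nM, which is a limit of the assay and not a number. Compound 2 `CCOC(=O)c1c(-c2cccc(OC(F)(F)F)c2)[nH]c2cc(OC)ccc2c1=O` gives > 21500 nM, again a limit and not a number.

Compound 3 `CCOC(=O)c1c(-c2cccc(Cl)c2)[nH]c2cc(OC)ccc2c1=O` differs from compound 2 at one place, with chloro in place of trifluoromethoxy on an aromatic carbon, meta to a large group: chloro in place of trifluoromethoxy on an aromatic carbon. Going by the values given here, no measured step exists in this assay, so the size of this one can only be expected. Compound 3 is expected to show no change beyond the scatter because compound 2 sits at the limit of > 21500 nM in this assay, at which 2 of the 2 values shown sit. The expected move, a step that the limit leaves unreadable from compound 2 to compound 3, is an estimate and a small one. The expected value for compound 3 is 25000 nM, within an estimated range of 12000 nM to 50000 nM.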

Compound 3, half-maximal effective concentration: > 21500 nM
Compound 3 ended at the assay's limit; the forecaster's own chance of this, stated with the estimate: 85%; the middle value is on the limit's open side.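

In this assay compound 3 gives > 21500 nM, a limit and not a number. Neither the step from compound 1 to compound 3 nor the step from compound 2 to compound 3 can be read, because all three compounds share one limit: the limit of > 21500 nM in this assay, at which 3 of the 3 values shown sit. The compounds shown leave open whether compound 1, compound 2 and compound 3 differ at all in this assay.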